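Swapping the chlorophenyl end of a diaryl urea for a thiophene

The compounds below may be only part of what the source reports. "The series", "measured", "known", "first", "only" and "open" are said of these compounds alone.

Of the compounds shown here, three sharing one core have been tested so far. Compound 1 `O=C(Nc1ccc(Cl)cc1)Nc1ccc(Oc2ccc(-c3nccs3)cc2)cc1` gives 32.5% in a functional assay on MDA-MB-231 cells (Homo sapiens) for inhibition, read by MTT assay and WST assay, with a stated time of 72 h, tested at 10 uM (a lower number here means less inhibition of growth, a higher number more inhibition of growth at the concentration tested), and this is the lowest of the three numbers. Compound 2 `O=C(Nc1ccc(Oc2ccc(-c3nccs3)cc2)cc1)Nc1ccc(Cl)c([N+](=O)[O-])c1` reaches 72.8%, and compound 3 `O=C(Nc1ccc(Oc2ccc(-c3nccs3)cc2)cc1)Nc1cc(C(F)(F)F)ccc1Cl` reaches 60.4%. Both changes away from compound 1 raised the number: a number 40.3 percentage points higher from compound 1 to compound 2 (beyond the scatter), and a number 27.9 percentage points higher from compound 1 to compound 3 (beyond the scatter). Between the two larger compounds the gap is smaller, a number 12.4 percentage points lower from compound 2 to compound 3 (beyond the scatter).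

Compound 4 `CC(=O)Oc1sccc1NC(=O)Nc1ccc(Oc2ccc(-c3nccs3)cc2)cc1` differs from compound 1 in one place: 2-acetoxythiophen-3-yl in place of 4-chlorophenyl on an amide-type nitrogen. This is a different kind of change from the two measured ones, which kept a six-membered ring of carbon only on that nitrogen and only added or moved substituents on it. Those steps show that this end of the molecule can shift the read-out substantially, but they give no direct guide for a five-membered ring bearing an acetoxy group. A cautious expectation is therefore a small upward move, a number 9.5 percentage points higher from compound 1 to compound 4 (within the scatter), with wide uncertainty. Compound 4 is estimated at 42%, within a range from 22% to 65%.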

Compound 4, percent growth inhibition at one concentration: 11%
Compound 4: middle estimate off by 31 percentage points, on the high side, and the stated range ends above it.
By their numbers in this assay, from the lowest: compound 4; then compound 1; then compound 3; then compound 2.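

In this assay, for the compounds shown here, the earlier steps away from compound 1 only raised the number, but this end of the molecule can also push the read-out down (a number 21.5 percentage points lower from compound 1 to compound 4 (beyond the scatter)). The drop is much larger when measured from the two compounds that carry more heavily substituted phenyl groups (a number 49.4 percentage points lower from compound 3 to compound 4 (beyond the scatter); a number 61.8 percentage points lower from compound 2 to compound 4 (beyond the scatter)), so among these four compounds the group on this amide-type nitrogen separates the lowest number from the highest. No measured evidence here bears on why the 2-acetoxythiophen-3-yl group gives a lower number than the 4-chlorophenyl group.

This one change replaces the ring and adds the acetoxy group together, so the compounds shown cannot separate the contribution of each. Going by these compounds, it remains open how a plain thiophen-3-yl group would behave, or one with an amine or a carboxylic acid in place of the acetoxy group.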